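Swapping the 4-Chlorophenyl Group of Compound 2

A few compounds are considered here, and "the series" means these few. Any claim that something is new, unique, unknown or untested is made for them only; others in the source may bear on it.

In a functional assay on MCF7 cells (Homo sapiens) for inhibition, read by MTT assay, with a stated time of 72 h (a higher number here means a weaker inhibitor, a lower number a stronger inhibitor), compound 2 `COc1cc(NC(C)CCCNC(=O)Nc2ccc(Cl)cc2)c2ncccc2c1` gives 12000 nM as the higher of the two measured numbers, and compound 1 `COc1cc(NC(C)CCCNC(=O)NNC(=O)Nc2ccc(C(F)(F)F)cc2)c2ncccc2c1` gives 100 nM as the lower, a gap beyond the scatter. Compound 3 `COc1cc(NC(C)CCCNC(=O)NNC(=O)Nc2cccc(Cl)c2)c2ncccc2c1` has ((3-chlorophenyl)carbamoyl)amino in place of 4-chlorophenyl on an amide-type nitrogen and awaits measurement. A large step to a lower number is expected in this assay because compound 1 with its shared carbamoylamino link gives 100 nM against the higher number of compound 2. The estimated change is a 40-fold lower number from compound 2 to compound 3 (1.60 log units; beyond the scatter) in that direction. For compound 3 the estimate is 300 nM with an expected range from 70 nM to 1500 nM in this measurement.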

Compound 3, half-maximal inhibitory concentration: 220 nM
Estimate against measurement, compound 3: 1.4-fold (0.13 log units) above; the range from low to high includes it.
By their numbers in this assay, from the lowest: compound 1; then compound 3; then compound 2.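

In this assay, ((3-chlorophenyl)carbamoyl)amino in place of 4-chlorophenyl on an amide-type nitrogen gives a 55-fold lower number from compound 2 to compound 3 (1.74 log units; beyond the scatter), so the large gap now appears across a change in one place. With the carbamoylamino link kept, 3-chlorophenyl in place of 4-(trifluoromethyl)phenyl gives a 2.2-fold higher number from compound 1 to compound 3 (0.34 log units; beyond the scatter), a modest step though beyond the scatter. No measured property is available to explain either step. From the compounds shown here alone, what 4-chlorophenyl would give on the same link remains open, as does the effect of an amine or a carboxylic acid on that phenyl ring.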